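The compounds below may be only part of what the source reports. "The series", "measured", "known", "first", "only" and "open" are said of these compounds alone.

Of the compounds shown here, three have been measured in an ADME assay on L1210 cells (Mus musculus) for cytotoxicity, with a stated time of 48 h; a lower number here means a stronger inhibitor, a higher number a weaker inhibitor. There compound 1 `C=C1[C@H](C)CCC[C@]1(C)CC/C(C)=C/CC1=C(O)C(=O)C=C(N[C@@H](C(=O)O)[C@H](C)O)C1=O` gives 4.6 ug/mL, compound 2 `CC1=CCC[C@](C)(CC/C(C)=C/CC2=C(O)C(=O)C=C(N[C@@H](C(=O)O)C(C)C)C2=O)[C@@H]1C` gives 3 ug/mL and compound 3 `CC1=CCC[C@H]2[C@](C)(CC3=C(O)C(=O)C=C(N[C@@H](CO)C(=O)O)C3=O)[C@@H](C)CC[C@]12C` gives 3.8 ug/mL. Compound 1 thus stands within the scatter of both others, and the numbers do not separate the three.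

Compound 4 `C=C1[C@H](C)CCC[C@]1(C)CC/C(C)=C/CC1=C(O)C(=O)C=C(N[C@H](C(=O)O)C(C)C)C1=O` keeps the core of compound 1 and differs from it in one place: 1-carboxy-2-methylpropyl in place of 1-carboxy-2-hydroxypropyl on an amine nitrogen. In words, 1-carboxy-2-methylpropyl stands in place of 1-carboxy-2-hydroxypropyl on an amine nitrogen. Within the data shown here, no step between measured compounds isolates this change, so the evidence is indirect. Compound 2 also carries a 1-carboxy-2-methylpropyl group on a different core, and it gives 3 ug/mL, which lies within the scatter of the other two values. On that basis, the expected step of a 1.2-fold lower number from compound 1 to compound 4 (0.08 log units; within the scatter) in this assay is none beyond the scatter. For compound 4 the estimated value is 3.8 ug/mL, with an expected range from 2 ug/mL to 7.5 ug/mL.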

Compound 4, half-maximal inhibitory concentration: 4.4 ug/mL
Compound 4: the middle estimate sits 1.2-fold (0.06 log units) below what was measured; the measured number falls inside the stated range.
By their numbers in this assay, from the lowest: compounds 2, 3, 4 and 1 (each within the scatter of the next).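

In this assay, the exchange of 1-carboxy-2-hydroxypropyl for 1-carboxy-2-methylpropyl on the amine nitrogen gives a 1.0-fold lower number from compound 1 to compound 4 (0.02 log units; within the scatter). The earlier compounds shown here carried their side chains on different cores, whereas here the core stays fixed and the two groups cannot be told apart in this assay, even though the entering group has fewer hydrogen-bond donors and acceptors. No measurement at hand offers an explanation for this result.

The compounds shown leave open whether a side chain ending in an amine, or one carrying a phenyl ring or a longer alkyl chain, would separate from these groups on the core of compound 1. They also leave open whether a methyl ester or a primary amide in place of the carboxylic acid would change the number.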